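A few compounds are considered here, and "the series" means these few. Any claim that something is new, unique, unknown or untested is made for them only; others in the source may bear on it.

Measured compounds:
compound 1, `COc1cc2c(Oc3ccc(NC(=O)c4nn(-c5ccccc5C(F)(F)F)c(=O)cc4C)cc3F)ccnc2cc1OCCCN1CCCCC1`; in a functional assay on MKN-45 cells (Homo sapiens) for inhibition, read by MTT assay, with a stated time of 72 h (a lower number here means a stronger inhibitor, a higher number a weaker inhibitor), compound 1 gives 90 nM
compound 2, `COc1cc2c(Oc3ccc(NC(=O)c4nn(-c5cccc(F)c5)c(=O)cc4C)cc3F)ccnc2cc1OCCCN1CCCC1`; in this assay compound 2 gives 120 nM

Compound 2 stands at one end of the two numbers shown; the only other number, that of compound 1, lies within the usual scatter of it, so the two cannot be told apart on these data. Among the measured compounds shown here, compound 1 and compound 2 differ in two places at once, the ring on the saturated chain and the aryl on the shared core, so no single step between measured compounds can be read off.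

Compound 3, `COc1cc2c(Oc3ccc(NC(=O)c4nn(-c5cccc(F)c5)c(=O)cc4C)cc3F)ccnc2cc1OCCCN1CCCCC1`, is not yet measured. It differs from compound 2 in one place: piperidin-1-yl in place of pyrrolidin-1-yl on a saturated chain carbon, three bonds along the chain from an oxygen on an aromatic ring. For the measured compounds named here, the one measured pair that spans this ring change also carries the aryl change, so nothing isolates the ring change alone. Given that compound 1 at 90 nM and compound 2 at 120 nM sit within the scatter of each other despite both changes, the expectation for compound 3 in this assay is no step beyond the scatter, a 1.2-fold lower number from compound 2 to compound 3 (0.08 log units; within the scatter). Compound 3 is estimated at 100 nM in this assay, with a range from 45 nM to 250 nM.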

Compound 3, half-maximal inhibitory concentration: 130 nM
Compound 3: middle estimate off by 1.3-fold (0.11 log units), on the low side; measured number inside the range.
By their numbers in this assay, from the lowest: compounds 1, 2 and 3 (each within the scatter of the next).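

Compound 2 and compound 3 isolate the ring change: piperidin-1-yl in place of pyrrolidin-1-yl on a saturated chain carbon, three bonds along the chain from an oxygen on an aromatic ring, gives a 1.1-fold higher number from compound 2 to compound 3 (0.03 log units; within the scatter) in this assay, so the two compounds cannot be told apart at this position with 3-fluorophenyl on the aromatic nitrogen. Compound 1 and compound 3 isolate the aryl change: with piperidin-1-yl held constant, 3-fluorophenyl in place of 2-(trifluoromethyl)phenyl on an aromatic nitrogen gives a 1.4-fold higher number from compound 1 to compound 3 (0.16 log units; within the scatter), so neither single change, read on its own, separates the compounds in this assay. No supporting data bear on these two results.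

Among the compounds shown here, the ring step is read with only one aryl and the aryl step with only one ring, so it remains open whether pyrrolidin-1-yl and piperidin-1-yl would also be indistinguishable with 2-(trifluoromethyl)phenyl on the aromatic nitrogen. Also open, from the compounds shown here alone, is whether a morpholine ring or a dimethylamino group at the end of the chain, a shorter 2-(piperidin-1-yl)ethyl chain, or an unsubstituted phenyl on the aromatic nitrogen would give a step beyond the scatter.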